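The source may report more compounds than this note shows. Statements on the series, on what has been measured and on what is new or still open speak of the compounds shown alone.

Measured in an ADME assay on MT4 cells (Homo sapiens) for cytotoxicity; a higher number here means that more compound is tolerated, a lower number that less compound is tolerated:
- compound 1 `CC(=O)OC[C@H]1O[C@@H](n2cc(-c3cc(-c4ccccc4)no3)c(=O)[nH]c2=O)C[C@@H]1OC(C)=O`: 3000 nM
- compound 2 `CC(C)(C)c1ccc(-c2cc(-c3cn([C@H]4C[C@H](O)[C@@H](CO)O4)c(=O)[nH]c3=O)on2)cc1`: 3000 nM

In this assay compound 1 stands at 3000 nM, level with compound 2 at the digits shown. Compound 3 `CC(=O)OC[C@H]1O[C@@H](n2cc(-c3cc(-c4ccc(C(C)C)cc4)no3)c(=O)[nH]c2=O)C[C@@H]1OC(C)=O` departs from compound 1 by isopropyl in place of hydrogen on an aromatic carbon, or phenyl to 4-isopropylphenyl. For the measured compounds named here, no measured pair isolates this change. Going by the values given here, with compound 2 at 3000 nM as the only other reading, no step beyond the scatter is expected in this assay, in either direction. The expected step is no change at the digits printed from compound 1 to compound 3 (within the scatter). Compound 3 is estimated at 3000 nM, with an expected range of 1200 nM to 8000 nM.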

Compound 3, half-maximal cytotoxic concentration: 3000 nM
For compound 3 middle estimate and measured number coincide at the digits printed, within the range that was stated.
By their numbers in this assay, from the lowest: compounds 1, 2 and 3 (each within the scatter of the next).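

Going from phenyl to 4-isopropylphenyl, on an aromatic carbon para to a large group, gives no change at the digits printed from compound 1 to compound 3 (within the scatter) in this assay. For the compounds shown here, this is the first one-place step, and it shows that this position can carry isopropyl in place of hydrogen with no step beyond the scatter. No evidence on hand bears on this result.

Going by these compounds alone, only this one group has been read at this position. On these data alone, whether an amine, a carboxylic acid or a longer alkyl chain in the same place would also leave the reading level remains open.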